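This account rests on a few compounds, and the source may have more. Where it says the series, first, only, none or still open, it means among the compounds named here.

Series notes. Three compounds have numbers in a functional assay on MKN-45 cells (Homo sapiens) for antiproliferative activity, with a stated time of 72 h; a higher number here means a weaker inhibitor, a lower number a stronger inhibitor. Compound 1 `Cn1cc(-c2ccc(NC(=O)c3cn(CC4CCOCC4)cc(-c4ccc(Cl)cc4)c3=O)cc2)c2c(N)ncnc21` gives 347 nM, the highest number of the three. Compound 3 `Nc1ncnc2[nH]cc(-c3ccc(NC(=O)c4cn(CC5CCOCC5)cc(-c5ccc(F)cc5)c4=O)cc3)c12` gives 77.9 nM, and compound 2 `Nc1ncnc2[nH]cc(-c3cc(F)c(NC(=O)c4cn(CC5CCOCC5)cc(-c5ccc(F)cc5)c4=O)cc3F)c12` gives 29.8 nM, both well past the scatter from compound 1, so compound 1 stands as the weakest of the measured set.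

The next step is to compound 4 `Cn1cc(-c2ccc(NC(=O)c3cn(CC4CCOCC4)cc(-c4ccc(C(F)(F)F)cc4)c3=O)cc2)c2c(N)ncnc21`, which differs from compound 1 only in this: trifluoromethyl in place of chloro on an aromatic carbon, on an aromatic carbon of a six-membered carbon-only aromatic ring, para to a large group. Within the data shown here, no measured pair shows this exchange, so the expectation is a step of modest size, likely within the scatter, with no firm direction. Compound 4 is expected to give 420 nM (range 150 nM to 1200 nM), the step of a 1.2-fold higher number from compound 1 to compound 4 (0.08 log units; within the scatter) being an estimate only.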

Compound 4, half-maximal inhibitory concentration: 826 nM
Compound 4: the middle estimate sits 2.0-fold (0.29 log units) below what was measured; the measured number falls inside the stated range.
By their numbers in this assay, from the lowest: compound 2; then compound 3; then compound 1; then compound 4.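

At this position, para to a large group, the substituent does matter in this assay: trifluoromethyl in place of chloro gives a modest loss (a 2.4-fold higher number from compound 1 to compound 4 (0.38 log units; beyond the scatter)), beyond the scatter. Among these compounds, this is the first single-change reading, and it sets 4-(trifluoromethyl)phenyl behind 4-chlorophenyl on the core of compound 1. No evidence at hand accounts for this step.

As far as these compounds go, how a methoxy group or a nitrile would fare at this position remains open. Compound 2 and compound 3 differ from compound 1 in more than one place, so they cannot settle the role of this substituent.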